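Aryl amide swap on the shared core

This account rests on a few compounds, and the source may have more. Where it says the series, first, only, none or still open, it means among the compounds named here.

Three compounds of the series have been run in an ADME assay on HepG2 cells (Homo sapiens) for inhibition, read by luminescence and CellTiter-Glo, with stated times of 24 h and 48 h; a lower number here means a stronger inhibitor, a higher number a weaker inhibitor. Compound 1 `O=C(CN(Cc1ccc(C(=O)NO)cc1)C(=O)c1cccc2ccccc12)NCc1ccccc1` gives 12800 nM, the upper of the two plain numbers shown. The other, compound 2 `Cc1ccc(C(=O)N(CC(=O)NC2CCCCC2)Cc2ccc(C(=O)NO)cc2)c(C)c1` with 8330 nM, lies within the scatter of compound 1, so the two are not distinguished. Compound 3 `Cc1cc(C)cc(C(=O)N(CC(=O)N(C)C)Cc2ccc(C(=O)NO)cc2)c1` returns only a limit of the assay, > 50000 nM. Such a limit, (the limit of > 50000 nM in this assay, at which 1 of the 3 values shown sits), stands for one of the three values.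

Among the compounds with values here, no pair of measured compounds differs in a single place, so no measured step size is available for the series.

Compound 4 `Cc1ccccc1C(=O)N(CC(=O)NCc1ccccc1)Cc1ccc(C(=O)NO)cc1` is the next candidate and differs from compound 1 in one place: 2-methylphenyl in place of naphthalen-1-yl on a carbonyl carbon. Nothing measured here speaks to this change, so the expected step of a 1.3-fold higher number from compound 1 to compound 4 (0.10 log units; within the scatter) is set at none beyond the scatter, with a slight lean toward the weaker side. Compound 4 is therefore estimated at 16000 nM in this assay, with a range from 5000 nM to 50000 nM.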

Compound 4, half-maximal inhibitory concentration: 9620 nM
The estimate for compound 4 lay 1.7-fold (0.22 log units) above the measured number; the measured number falls inside the stated range.
By their numbers in this assay, from the lowest: compounds 2, 4 and 1 (each within the scatter of the next). At a limit, above all of these: compound 3.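

The series now has its first step in one place: in this assay, putting 2-methylphenyl in place of naphthalen-1-yl on a carbonyl carbon gives a 1.3-fold lower number from compound 1 to compound 4 (0.12 log units; within the scatter), which lies within the scatter. At this position, one of the two six-membered aromatic rings of carbon only can therefore go without a change that this assay can distinguish. No measured property in hand bears on this step.

All the groups shown on this carbonyl carbon are aromatic rings of carbon only, so it remains open whether a pyridine ring or a phenyl ring carrying a carboxylic acid or an amine would give a step beyond the scatter. Compound 3 gives a limit of the assay, > 50000 nM, and it differs from the other compounds in more than one place, so no single change can be tied to that limit.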